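Chain lengthening on the shared core: propyl to butyl

The source may hold more compounds than are shown below. What is called first, only, known or untested is meant among the compounds shown, and "the series" means these compounds.

Three compounds of the series have a number in a functional assay on the whole organism (strain Sprague-Dawley) for inhibition, with Rattus norvegicus as the target, read by paw edema, with a stated time of 3 h, at a dose of 150 mg/kg by the oral route; a lower number here means less inhibition, a higher number more inhibition at the dose given (going by the name of the read-out). Compound 3 `CCCN1N=C2/C(=C/c3ccccc3)CN(C)CC2C1c1ccccc1` stands highest of the three, giving 47% in this assay. Compound 1 `CN1C/C(=C\c2ccccc2)C2=NN(C)[C@@H](c3ccccc3)[C@@H]2C1` gives 22% in this assay, a number that lies beyond the scatter below compound 3. Compound 2 `CN1N=C2/C(=C/c3ccccc3)CN(Cc3ccccc3)CC2C1c1ccccc1` gives 0% in this assay, the furthest from compound 3 and again beyond the scatter. Within the data shown here, compound 1 and compound 3 differ in the chain carried on the core, but no single step between them is set out, so their two values alone show that the longer chain of compound 3 goes with the higher number.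

Compound 4 `CCCCN1N=C2/C(=C/c3ccccc3)CN(C)CC2C1c1ccccc1` is not yet measured. It differs from compound 3 in one place: methyl in place of hydrogen on a saturated chain carbon, three bonds along the chain from an amine nitrogen in a ring. The change adds one carbon to the chain and nothing else. On the record of compound 3 at 47%, the step from propyl to butyl is expected to stay within the scatter, with at most a slight rise, so the expected step is a number 3 percentage points higher from compound 3 to compound 4 (within the scatter). Compound 4 is accordingly estimated at 50% in this assay, within a range from 30% to 70%.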

Compound 4, a percentage reported as inhibition, in the whole organism at one dose (the size of the read-out at that dose, not a potency): 26%
Beside the measured number, compound 4's estimate is 24 percentage points above it; the measured number lies below the stated range.
By their numbers in this assay, from the lowest: compound 2; then compounds 1 and 4 (each within the scatter of the next); then compound 3.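

In this assay, among these compounds, the change from propyl to butyl gives a number 21 percentage points lower from compound 3 to compound 4 (beyond the scatter), the only step read between two compounds that differ in one place. It shows that the number at this dose responds to a single added carbon at this position, three bonds along the chain from an amine nitrogen in a ring, and that here the longer chain goes with the lower number. No measurement among the compounds shown accounts for this fall.

From the compounds shown here alone, whether the number falls further with a longer chain such as pentyl remains open. Also open, going by these compounds, is how a branched chain such as isopropyl, or a propyl chain ending in a hydroxyl group, would compare with the propyl of compound 3.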